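Swapping Isopropyl for Isobutyl on a Weak Growth Inhibitor

A few compounds are considered here, and "the series" means these few. Any claim that something is new, unique, unknown or untested is made for them only; others in the source may bear on it.

- compound 1 `CCC1C(=O)N(C)c2cnc(-n3ccc4cc(C(=O)NC(C)C)ccc43)nc2N1c1ccn(C)n1` gives 8910 nM
- compound 2 `CC[C@@H]1C(=O)N(C)c2cnc(Nc3ccc(S(=O)(=O)NCCCO)cc3)nc2N1C1CCCC1` gives 331 nM
- compound 3 `CC[C@@H]1C(=O)N(C)c2cnc(-n3ccc4cc(C(=O)NC)ccc43)nc2N1C1CCCC1` gives 705 nM

All three values come from a functional assay on K562 cells (Homo sapiens) for antiproliferative activity, read by CCK-8 assay, with a stated time of 72 h; on this read-out lower numbers stand for stronger inhibition of growth and higher numbers for weaker inhibition of growth. Compound 1 has the highest number of the three, so it is the weakest growth inhibitor in this small set. Its value lies beyond the usual scatter of repeated measurements from both of the others. However, compound 1 differs from compound 2 and compound 3 in more than one place, so these gaps cannot be traced to any single group.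

Compound 4 `CCC1C(=O)N(C)c2cnc(-n3ccc4cc(C(=O)NCC(C)C)ccc43)nc2N1c1ccn(C)n1` changes compound 1 in one place only: isobutyl in place of isopropyl on an amide-type nitrogen. This puts isobutyl in place of isopropyl on an amide-type nitrogen. For the measured compounds named here, no pair of measured compounds shows this swap or any other single change, so the data offer no direct guide to its effect. With only a small change to the side chain, compound 4 is expected to stay close to compound 1 at 8910 nM, with no shift beyond the scatter in this assay in either direction. The expected size of the change is a 1.1-fold lower number from compound 1 to compound 4 (0.05 log units; within the scatter). For compound 4 the estimated value is 8000 nM, with an expected range from 3000 nM to 20000 nM.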

Compound 4, concentration for 50% growth inhibition: 5600 nM
The estimate for compound 4 lay 1.4-fold (0.15 log units) above the measured number, and the stated range covers the measured number.
By their numbers in this assay, from the lowest: compound 2; then compound 3; then compounds 4 and 1 (each within the scatter of the next).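

In this assay, putting isobutyl in place of isopropyl on the amide-type nitrogen gives a 1.6-fold lower number from compound 1 to compound 4 (0.20 log units; within the scatter) and so leaves the two compounds indistinguishable on this read-out. For the compounds shown here, this is the first comparison in the set that isolates a single place, which the earlier compounds could not do because they differ from one another in several places at once. It shows that, on this core, adding one carbon to this branched chain produces no change that can be separated from ordinary assay variation, although a single pair cannot show how the position responds to larger changes. Nothing available here offers an explanation for how closely the two compounds read.

Going by these compounds, it remains open whether this position would respond as little to groups of a different kind, such as a primary amine or a carboxylic acid carried on a longer chain, or a cyclopropyl ring on the same nitrogen. On these data alone, it is also open whether the isopropyl to isobutyl swap would read the same way on a compound with a different group elsewhere on the core, such as the cyclopentyl group of compound 3.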